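Methoxy in place of bromo: what three values suggest

The compounds below may be only part of what the source reports. "The series", "measured", "known", "first", "only" and "open" are said of these compounds alone.

Measured in a functional assay on P388 cells (Mus musculus) for antiproliferative activity, read by colorimetric assay and MTT assay; on this read-out lower numbers stand for stronger inhibition and higher numbers for weaker inhibition:
- compound 1 `Nc1ccc(S(=O)(=O)Nc2ccc(Cl)c3c(Cl)c[nH]c23)cc1`: 0.49 ug/mL
- compound 2 `Nc1ccc(S(=O)(=O)Nc2ccc(F)c3c(Cl)c[nH]c23)cc1`: 0.51 ug/mL
- compound 3 `Nc1ccc(S(=O)(=O)Nc2ccc(Br)c3c(Cl)c[nH]c23)cc1`: 0.64 ug/mL

Compound 3 stands level with the other two compounds. The measured steps to it are a 1.3-fold higher number from compound 1 to compound 3 (0.12 log units; within the scatter) and a 1.3-fold higher number from compound 2 to compound 3 (0.10 log units; within the scatter), and neither exceeds the usual scatter of repeated measurements.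

The next compound is compound 4 `COc1ccc(NS(=O)(=O)c2ccc(N)cc2)c2[nH]cc(Cl)c12`, in which methoxy replaces bromo on an aromatic carbon, para to a large group (methoxy in place of bromo on an aromatic carbon). Among the compounds with values here, the steps that bear on this change are the exchanges at that same carbon. Besides the two above, there is a 1.0-fold higher number from compound 1 to compound 2 (0.02 log units; within the scatter), with fluoro in place of chloro. All three are small, but none involves methoxy, so they offer only indirect guidance. On this evidence, no step beyond the scatter is expected in this assay, and neither direction is favoured. The lack of any methoxy measurement calls for a wider range than the three values alone would suggest.

Expressed as a step, the expected change is a 1.1-fold lower number from compound 3 to compound 4 (0.03 log units; within the scatter). For compound 4 the estimated value is 0.6 ug/mL, with an expected range from 0.25 ug/mL to 1.5 ug/mL.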

Compound 4, half-maximal inhibitory concentration: 5.5 ug/mL
Beside the measured number, compound 4's estimate is 9.2-fold (0.96 log units) below it; the measured number lies above the stated range.
By their numbers in this assay, from the lowest: compounds 1, 2 and 3 (each within the scatter of the next); then compound 4.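

In this assay, exchanges among chloro, fluoro and bromo on this aromatic carbon had produced no step beyond the scatter, so the position could have seemed indifferent to its substituent, but methoxy ends that picture: the result is an 8.6-fold higher number from compound 3 to compound 4 (0.93 log units; beyond the scatter), an 11-fold higher number from compound 2 to compound 4 (1.03 log units; beyond the scatter) and an 11-fold higher number from compound 1 to compound 4 (1.05 log units; beyond the scatter). All three steps lie beyond the scatter and point the same way, towards weaker inhibition, so compound 4 stands apart from all three halogen compounds, whichever halogen it is compared with. The position therefore does respond to its substituent once a single halogen atom gives way to methoxy, with its two heavy atoms and one hydrogen-bond acceptor, though no measurement given here accounts for the shift.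

On these data alone, what stays open is whether the oxygen or the added carbon of methoxy goes with the weaker inhibition, a question that a hydroxy group or a methyl group on this carbon could help to separate. As far as these compounds go, it is equally open whether an amine would read like the halogens or like methoxy, and whether a longer chain such as ethoxy would move the number further.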